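The source may hold more compounds than are shown below. What is called first, only, known or untested is meant among the compounds shown, and "the series" means these compounds.

Three close relatives share one core and differ only in the aromatic ring at the end of the chain. Compound 1 `CC1=C(/C=C/C(=O)/C=C/c2ccccc2)C(C)(C)CCC1` carries an unsubstituted phenyl ring, and in a functional assay on MCF7 cells (Homo sapiens) for cytotoxicity, read by sulforhodamine B assay, with a stated time of 48 h (a higher number here means a weaker inhibitor, a lower number a stronger inhibitor), compound 1 gives 10600 nM. Compound 2 `CC1=C(/C=C/C(=O)/C=C/c2ccc(F)cc2)C(C)(C)CCC1` carries a fluoro group on that ring, and in this assay compound 2 gives 6200 nM. Compound 3 `CC1=C(/C=C/C(=O)/C=C/c2ccc(C)cc2)C(C)(C)CCC1` carries a methyl group instead, and in this assay compound 3 gives 23800 nM, the highest of the three numbers. The steps show a 1.7-fold lower number from compound 1 to compound 2 (0.23 log units; within the scatter), a 2.2-fold higher number from compound 1 to compound 3 (0.35 log units; beyond the scatter) and a 3.8-fold higher number from compound 2 to compound 3 (0.58 log units; beyond the scatter).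

Compound 4 `CC1=C(/C=C/C(=O)/C=C/c2ccccc2Br)C(C)(C)CCC1` makes a further change: 2-bromophenyl in place of 4-methylphenyl on a double-bonded chain carbon bound to a double-bonded chain carbon. Among the compounds with values here, two measured steps bear on it. The methyl group that leaves is the one whose arrival raised the number in the step from compound 1 to compound 3, so its loss is expected to bring the number back down by a modest amount. A halogen entering the ring, as in the step from compound 1 to compound 2, changed the number only within the scatter. Taken together, the expected step is a 2.6-fold lower number from compound 3 to compound 4 (0.42 log units; beyond the scatter). Compound 4 is therefore estimated at 9000 nM, within a range of 3500 nM to 25000 nM.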

Compound 4, half-maximal inhibitory concentration: 20700 nM
For compound 4 the middle estimate is 2.3-fold (0.36 log units) below the measured one; the range from low to high includes it.
By their numbers in this assay, from the lowest: compounds 2, 1, 4 and 3 (each within the scatter of the next, the first and the last beyond it).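

In this assay the change to 2-bromophenyl from 4-methylphenyl gives a 1.1-fold lower number from compound 3 to compound 4 (0.06 log units; within the scatter) and so leaves the two compounds indistinguishable, while bromo in place of hydrogen gives a 2.0-fold higher number from compound 1 to compound 4 (0.29 log units; within the scatter) and also stays within the scatter. A halogen on this ring therefore does not settle the number by itself: 2-bromophenyl in place of 4-fluorophenyl gives a 3.3-fold higher number from compound 2 to compound 4 (0.52 log units; beyond the scatter) and separates the two halogen-bearing compounds beyond the scatter. Nothing available explains this gap between compound 2 and compound 4.

Since 4-fluorophenyl and 2-bromophenyl differ both in the halogen and in where it sits on the ring, the compounds shown cannot tell which of the two matters. As far as these compounds go, how the ring would fare with an amine or a carboxylic acid in place of the halogen also remains open.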